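Swapping anilino for piperidin-1-yl in compound 2

A few compounds are considered here, and "the series" means these few. Any claim that something is new, unique, unknown or untested is made for them only; others in the source may bear on it.

Compound 1 `Cc1ccc(C)c(NC(=O)Nc2nc(Sc3c[nH]c4ccccc34)cc(N3CCCCC3)n2)c1`: 5940 nM
Compound 2 `O=C(Nc1ccccc1)Nc1nc(Nc2ccccc2)cc(Sc2c[nH]c3ccccc23)n1`: 35900 nM
Compound 3 `Cc1cc(Cl)ccc1NC(=O)Nc1nc(Nc2ccccc2)cc(Sc2c[nH]c3ccccc23)n1`: 17100 nM

All three numbers come from a functional assay on MDA-MB-231 cells (Homo sapiens) for inhibition, with a stated time of 72 h; a lower number here means a stronger inhibitor, a higher number a weaker inhibitor. Compound 2 has the highest number of the three, which makes it the weakest inhibitor here. Compound 4 `O=C(Nc1ccccc1)Nc1nc(Sc2c[nH]c3ccccc23)cc(N2CCCCC2)n1` keeps everything in compound 2 except one group, with piperidin-1-yl in place of anilino on an aromatic carbon.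

Among the compounds with values here, no measured step makes exactly this change. Within the data shown here, the one measured step, a 2.1-fold lower number from compound 2 to compound 3 (0.32 log units; beyond the scatter), is modest and alters the phenyl on an amide-type nitrogen instead. Among the measured compounds shown here, compound 1 is the only measured compound carrying piperidin-1-yl, and compound 1 gives 5940 nM, but it also has a substituted phenyl on that nitrogen. Compound 4 lacks that substitution, so it is expected to lie above compound 1 yet below compound 2. The expected change is a 3.0-fold lower number from compound 2 to compound 4 (0.48 log units; beyond the scatter). For compound 4 the estimate is 12000 nM, with an expected range from 5000 nM to 28000 nM.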

Compound 4, half-maximal inhibitory concentration: 8130 nM
Compound 4: middle estimate off by 1.5-fold (0.17 log units), on the high side, within the range that was stated.
By their numbers in this assay, from the lowest: compounds 1 and 4 (each within the scatter of the next); then compound 3; then compound 2.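

In this assay, the swap of anilino for piperidin-1-yl on this aromatic carbon can now be read on its own, and it gives a 4.4-fold lower number from compound 2 to compound 4 (0.65 log units; beyond the scatter). The aromatic anilino ring is therefore not needed at this position for inhibition, and a non-aromatic ring gives a stronger inhibitor in this pair. With piperidin-1-yl in place, a 1.4-fold higher number from compound 1 to compound 4 (0.14 log units; within the scatter), so the 2,5-dimethylphenyl and phenyl groups on the amide-type nitrogen cannot be told apart here, and no measurement shown explains either result.

Going by these compounds, how a morpholin-4-yl or a dimethylamino group on this carbon would compare with piperidin-1-yl remains open. Also open, on these data alone, is whether 4-chloro-2-methylphenyl on the amide-type nitrogen would still lower the number when piperidin-1-yl is present.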